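Sulfonate Ester Exchanged for a Diarylamine on a Shared Core

The compounds below may be only part of what the source reports. "The series", "measured", "known", "first", "only" and "open" are said of these compounds alone.

Compound 1 `C=C[C@@](C)(/C=C/c1ccc(OS(=O)(=O)C(F)(F)F)cc1)CCC=C(C)C` is measured in a functional assay on SEM cells (Homo sapiens) for cytotoxicity, with a stated time of 72 h (on this read-out higher numbers stand for an effect only at larger amounts of compound and lower numbers for an effect already at smaller amounts), and gives only a limit there, > 36600 nM. Compound 2 `C=C[C@@](C)(/C=C/c1ccc(OS(=O)(=O)c2ccc(C)cc2)cc1)CCC=C(C)C` gives only a limit as well, > 43400 nM. The step that the two limits leave unreadable from compound 1 to compound 2 is therefore not readable. For the measured compounds named here, compound 3 `COc1ccc(/C=C/[C@@](C)(/C=C/c2ccc(O)c(C=O)c2)CCC=C(C)C)cc1`, which carries a different set of substituents on the shared core, gives 4550 nM in this assay, the only number among the three. Compound 4 `C=C[C@@](C)(/C=C/c1ccc(Nc2ccc(Cl)cc2)cc1)CCC=C(C)C` differs from compound 1 in one place, on an aromatic carbon para to a large group: (4-chlorophenyl)amino in place of ((trifluoromethyl)sulfonyl)oxy on an aromatic carbon. Going by the values given here, no measured step speaks to this exchange; the two limits the limit of > 36600 nM in this assay, at which 1 of the 3 values shown sits, and the limit of > 43400 nM in this assay, at which 1 of the 3 values shown sits, show only that compound 1 and compound 2 do not reach an effect within the measured range. Compound 4 is expected to give 20000 nM, within a range from 4000 nM to 80000 nM. The step of an at least 1.8-fold lower number from compound 1 to compound 4 (0.26 log units; that floor lies within the scatter) expected from this is uncertain because compound 1 stands at the limit of > 36600 nM in this assay, at which 1 of the 3 values shown sits, so compound 4 may well return only a limit again.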

Compound 4, half-maximal effective concentration: > 36600 nM
Compound 4 was reported as a limit (the forecaster's own chance of this, stated with the estimate: 45%); at least 1.8-fold (0.26 log units) between middle value and limit.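

Like compound 1, compound 4 returns only a limit in this assay, > 36600 nM, so no step between the two can be read. The compounds shown leave open whether exchanging ((trifluoromethyl)sulfonyl)oxy for (4-chlorophenyl)amino on the shared core changes the concentration needed for an effect at all.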